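The source may hold more compounds than are shown below. What is called first, only, known or untested is meant among the compounds shown, and "the series" means these compounds.

Of the compounds shown here, two have a number so far. Compound 1 `C#CCOc1cccc(/C=N/Cc2ccc(S(N)(=O)=O)cc2)c1` gives 104000 nM in a functional assay on HT-29 cells (Homo sapiens) for cytotoxicity, read by MTT assay, with a stated time of 24 h (on this read-out higher numbers stand for weaker inhibition and lower numbers for stronger inhibition), and compound 2 `O=Cc1ccccc1OCc1cn(CCCOc2ccc3ccc(=O)oc3c2)nn1` gives 18900 nM in this assay; compound 2 thus holds the lower number of the two, and the gap to compound 1 lies beyond the scatter. Compound 3 `COc1cccc(C=O)c1OCc1cn(CCCOc2ccc3ccc(=O)oc3c2)nn1` has not been measured. It differs from compound 2 by methoxy in place of hydrogen on an aromatic carbon, which reads as methoxy in place of hydrogen on an aromatic carbon. Within the data shown here, no measured pair shows this change, so compound 3 is estimated to give 18000 nM (range 6000 nM to 55000 nM), a step of a 1.1-fold lower number from compound 2 to compound 3 (0.02 log units; within the scatter) expected to stay within the scatter.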

Compound 3, half-maximal inhibitory concentration: 13300 nM
For compound 3 the middle estimate is 1.4-fold (0.13 log units) above the measured one; the range from low to high includes it.
By their numbers in this assay, from the lowest: compounds 3 and 2 (each within the scatter of the next); then compound 1.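

In this assay methoxy in place of hydrogen on an aromatic carbon, ortho to a large group and meta to a formyl group, gives a 1.4-fold lower number from compound 2 to compound 3 (0.15 log units; within the scatter) and so stays within the scatter. Among these compounds, this is the first measured example of this change, and it leaves compound 3 and compound 2 indistinguishable on this read-out. No supporting data bear on why this is so.

Open, on these data alone, is whether an amine, a carboxylic acid or a longer chain such as ethoxy at this position would shift the number beyond the scatter. Also open, as far as these compounds go, is whether methoxy would behave the same way at another position on this ring.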